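Small Sulfur Substituent: From Compound 3 to Compound 4

A few compounds are considered here, and "the series" means these few. Any claim that something is new, unique, unknown or untested is made for them only; others in the source may bear on it.

Measured in a functional assay on PC-9 cells (Homo sapiens) for inhibition, read by MTT assay, with a stated time of 72 h; a higher number here means a weaker inhibitor, a lower number a stronger inhibitor:
Compound 1 `Cc1cc(Nc2cc(-c3ccccc3)[nH]n2)n2nc(SCc3ccc(F)cc3)nc2n1`: 8110 nM
Compound 2 `Cc1cc(Nc2cc(-c3ccccc3)[nH]n2)n2nc(SCc3cccc(Br)c3)nc2n1`: 8900 nM
Compound 3 `C=CCSc1nc2nc(C)cc(Nc3cc(-c4ccccc4)[nH]n3)n2n1`: > 50000 nM (a limit)

Compound 3 gives only a limit, > 50000 nM. Compound 4 `Cc1cc(Nc2cc(-c3ccccc3)[nH]n2)n2nc(SCC3CC3)nc2n1` differs from it by cyclopropyl in place of vinyl on a saturated chain carbon bound to a sulfur. Among the measured compounds shown here, two measured steps bear on this place, an at least 6.1-fold higher number from compound 1 to compound 3 (0.78 log units; beyond the scatter) and an at least 5.6-fold higher number from compound 2 to compound 3 (0.74 log units; beyond the scatter), while a 1.1-fold higher number from compound 1 to compound 2 (0.04 log units; within the scatter). Neither of the first two compares vinyl with cyclopropyl, and compound 4, like compound 3, carries no phenyl group. A small change is therefore expected in this assay, with an at least 1.4-fold lower number from compound 3 to compound 4 (0.15 log units; that floor lies within the scatter) as the expected step. Compound 4 is estimated at 35000 nM, within a range of 12000 nM to 60000 nM.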

Compound 4, half-maximal inhibitory concentration: > 50000 nM
Compound 4: no number, only a limit; the forecaster's own chance of this, stated with the estimate: 45%; middle value at least 1.4-fold (0.15 log units) away from the limit.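

Cyclopropyl in place of 4-fluorophenyl gives an at least 6.1-fold higher number from compound 1 to compound 4 (0.78 log units; beyond the scatter), and in place of 3-bromophenyl it gives an at least 5.6-fold higher number from compound 2 to compound 4 (0.74 log units; beyond the scatter). Thus a saturated ring behaves here as the double bond of compound 3 did, and neither group without a phenyl ring gives a readable number. The steps between compound 3 and compound 4 cannot be read, as compound 4 also gives only a limit: the limit of > 50000 nM in this assay, at which 2 of the 4 values shown sit.

As far as these compounds go, whether a longer chain or an amine on this saturated chain carbon would give a number in this assay remains open. So does whether unsubstituted phenyl there would match the two halogenated phenyl groups.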